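The source may hold more compounds than are shown below. What is called first, only, known or untested is meant among the compounds shown, and "the series" means these compounds.

Compound 1 `OC1CCCN(c2nc(-c3ccccn3)nc3c2CN(Cc2ccccc2)CC3)C1` and compound 2 `NC(=O)CN1CCN(c2nc(-c3ccccn3)nc3c2CN(Cc2ccccc2)CC3)CC1` share one core and differ only in the group on the aromatic carbon of that core. In an assay on FRT cells with Cystic fibrosis transmembrane conductance regulator variant F508del (Homo sapiens) as the target, read by fluorescence, with a stated time of 25 min (on this read-out higher numbers stand for an effect only at larger amounts of compound and lower numbers for an effect already at smaller amounts), compound 1 gives 2800 nM, and compound 2 gives 2800 nM in this assay; the step of no change at the digits printed from compound 1 to compound 2 (within the scatter) shows the two standing level at the digits shown, so compound 1 sits at the same level as its single neighbour.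

Compound 3 `CN(C)CCN1CCN(c2nc(-c3ccccn3)nc3c2CN(Cc2ccccc2)CC3)CC1` is not yet measured. It differs from compound 1 by 4-(2-(dimethylamino)ethyl)piperazin-1-yl in place of 3-hydroxypiperidin-1-yl on an aromatic carbon. Within the data shown here, the only measured step that bears on such an exchange at this position is no change at the digits printed from compound 1 to compound 2 (within the scatter), where one piperazinyl group took the place of the same hydroxypiperidinyl group and left the value unchanged within the scatter. On that basis the step of no change at the digits printed from compound 1 to compound 3 (within the scatter) is expected to stay within the scatter, in neither direction. Compound 3 is therefore estimated at 2800 nM in this assay, with a range from 1200 nM to 6500 nM.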

Compound 3, half-maximal effective concentration: 1500 nM
Estimate against measurement, compound 3: 1.9-fold (0.27 log units) above; measured number inside the range.
By their numbers in this assay, from the lowest: compounds 3, 1 and 2 (each within the scatter of the next).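

In this assay the exchange of 3-hydroxypiperidin-1-yl for 4-(2-(dimethylamino)ethyl)piperazin-1-yl gives a 1.9-fold lower number from compound 1 to compound 3 (0.27 log units; within the scatter) even though the entering group has 11 heavy atoms against 7, and 0 hydrogen-bond donors against 1. This aromatic carbon therefore carries a group without a hydrogen-bond donor with no step beyond the scatter, which compound 2 did not show, since its carbamoyl group was still present. On the saturated chain carbon bound to an amine nitrogen in a ring, (dimethylamino)methyl in place of carbamoyl gives a 1.9-fold lower number from compound 2 to compound 3 (0.27 log units; within the scatter) and so adds a second change that stays within the scatter.

Going by these compounds, whether a carboxylic acid or a longer chain on that carbon would move the number beyond the scatter stays open. So does the effect of an open-chain amine on the aromatic carbon. Nothing given here accounts for these values.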